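The source may hold more compounds than are shown below. What is called first, only, known or untested is meant among the compounds shown, and "the series" means these compounds.

Working notes on the series.

Three compounds have been run in an assay (strain Wistar) for displacement of a labelled ligand from adenosine receptor A1 (Rattus norvegicus), read by scintillation counting; a higher number here means a weaker inhibitor, a lower number a stronger inhibitor. Compound 1 `O=C(Nc1nc(-c2ccccc2)nc2c1nnn2Cc1ccccc1)C1CCCCC1` gives 12 nM and compound 2 `Nc1ccc(C(=O)Nc2nc(-c3ccccc3)nc3c2nnn3Cc2ccccc2)cc1` gives 7.1 nM, the two separated by a 1.7-fold lower number from compound 1 to compound 2 (0.23 log units; within the scatter). Compound 3 `COc1ccccc1C(=O)Nc1nc(-c2ccccc2)nc2c1nnn2Cc1ccccc1` gives 1520 nM, the highest of the three numbers, set apart from the other two by a 130-fold higher number from compound 1 to compound 3 (2.10 log units; beyond the scatter) and a 210-fold higher number from compound 2 to compound 3 (2.33 log units; beyond the scatter).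

Compound 4 `O=C(Nc1nc(-c2ccccc2)nc2c1nnn2Cc1ccccc1)c1cccc(F)c1` is the next step from compound 3: 3-fluorophenyl in place of 2-methoxyphenyl on a carbonyl carbon. Going by the values given here, no measured pair shows this exchange directly. What bears on it is that the 2-methoxyphenyl group of compound 3 is the one feature held by the weakest member alone, and that both steps into it were large; removing that group in favour of another six-membered aromatic ring of carbon only is therefore expected to read back towards the numbers of compounds 1 and 2. Compound 4 is expected to give 25 nM in this assay, within 5 nM to 150 nM, an estimated step of a 61-fold lower number from compound 3 to compound 4 (1.78 log units; beyond the scatter) downward. Uncertainty remains, since only one aryl replacement has been tried on each side.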

Compound 4, inhibition constant: 22 nM
Compound 4: the middle estimate sits 1.1-fold (0.06 log units) above what was measured; the range from low to high includes it.
By their numbers in this assay, from the lowest: compounds 2, 1 and 4 (each within the scatter of the next, the first and the last beyond it); then compound 3.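

In this assay the position on the carbonyl carbon accepts a substituted phenyl ring with no large loss in every case: 3-fluorophenyl in place of 2-methoxyphenyl gives a large step (a 69-fold lower number from compound 3 to compound 4 (1.84 log units; beyond the scatter)), so the high number of compound 3 is not common to all substituted phenyl groups here. Against the cyclohexyl group the 3-fluorophenyl change stays within the scatter (a 1.8-fold higher number from compound 1 to compound 4 (0.26 log units; within the scatter)), whereas against the 4-aminophenyl group it is modest but beyond the scatter (a 3.1-fold higher number from compound 2 to compound 4 (0.49 log units; beyond the scatter)), a separation that compound 1 and compound 2 alone did not reveal. No available evidence accounts for these differences.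

The compounds shown leave open whether the high number of compound 3 follows the methoxy group itself or its place on the ring. From the compounds shown here alone, how a hydroxyl group, a chlorine atom or a carboxylic acid on the phenyl ring would read at this position also remains open.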